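Compound 4 and a second chloro: solubility expectation

The source may hold more compounds than are shown below. What is called first, only, known or untested is meant among the compounds shown, and "the series" means these compounds.

In a physicochemical assay for solubility, at pH 7.4 (on this read-out lower numbers stand for lower solubility and higher numbers for higher solubility), compound 1 `Cc1cc(NC(=O)Nc2cccc(Cl)c2)c2ccccc2n1` gives 800 nM, the lowest of the three numbers in hand, though the nearest neighbour sits within the scatter of it. Compound 2 `COc1cccc(NC(=O)Nc2cc(C)nc3ccccc23)c1` gives 1200 nM, and the step of a 1.5-fold higher number from compound 1 to compound 2 (0.18 log units; within the scatter) is methoxy in place of chloro on an aromatic carbon. Compound 3 `Cc1cc(NC(=O)Nc2ccccc2N)c2ccccc2n1` gives 51800 nM; the step of a 65-fold higher number from compound 1 to compound 3 (1.81 log units; beyond the scatter) is 2-aminophenyl in place of 3-chlorophenyl on an amide-type nitrogen. Compound 4 `Cc1cc(NC(=O)Nc2ccc(Cl)c(Cl)c2)c2ccccc2n1` has not yet been measured in this assay. It differs from compound 1 by chloro in place of hydrogen on an aromatic carbon. Neither measured step puts a chloro in place of hydrogen: one exchanges chloro for methoxy without a move beyond the scatter, the other replaces the whole group on the amide-type nitrogen and moves far upward. Going by the values given here, the step from compound 1 to compound 4 therefore has no close precedent. A modest downward move is expected, and it may well fall within the scatter. For compound 4 in this assay the expected value is 400 nM (range 150 nM to 1500 nM). This corresponds to an expected 2.0-fold lower number from compound 1 to compound 4 (0.30 log units; within the scatter).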

Compound 4, solubility: 300 nM
For compound 4 the middle estimate is 1.3-fold (0.12 log units) above the measured one, and the stated range covers the measured number.
By their numbers in this assay, from the lowest: compound 4; then compounds 1 and 2 (each within the scatter of the next); then compound 3.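

In this assay, going by these compounds alone, this is the first case of chloro in place of hydrogen, and a 2.7-fold lower number from compound 1 to compound 4 (0.43 log units; beyond the scatter) is a modest downward move beyond the scatter. The earlier steps shown here exchanged one substituent for another or replaced the whole group on the amide-type nitrogen, whereas this one shows that a single added chloro, ortho to a chloro group and para to a large group, is enough to lower the number with the rest of compound 1 unchanged. Nothing at hand accounts for the cause of this step.

From the compounds shown here alone, whether fluoro, methyl or a carboxylic acid at this position would move the number in the same direction remains open. Also open, going by these compounds, is whether the step depends on the chloro already present on that ring.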